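The source may hold more compounds than are shown below. What is called first, only, known or untested is meant among the compounds shown, and "the series" means these compounds.

Compound 1 `O=C(COc1cccc2ccccc12)N/N=C/c1cccc(O)c1` and compound 2 `O=C(COc1cccc2ccccc12)N/N=C/c1ccc([N+](=O)[O-])cc1` share one core and differ only in the group on the terminal aromatic ring. In an ADME assay on HEL cells (Homo sapiens) for cytotoxicity (a lower number here means that less compound is tolerated, a higher number that more compound is tolerated), compound 1 gives 100 ug/mL, whereas compound 2 gives 20 ug/mL, the lowest of the two numbers, with the gap to compound 1 lying beyond the scatter. Compound 3 `COc1ccc(/C=N/NC(=O)COc2cccc3ccccc23)cc1` is not yet measured; it differs from compound 2 by methoxy in place of nitro on an aromatic carbon. Within the data shown here, since no step between measured compounds is available for this change, the expected step from compound 2 to compound 3, a 2.5-fold higher number from compound 2 to compound 3 (0.40 log units; beyond the scatter), is judged modest and upward, toward the number of compound 1. Compound 3 is therefore estimated at 50 ug/mL, within a range from 20 ug/mL to 100 ug/mL.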

Compound 3, minimum cytotoxic concentration: 20 ug/mL
The estimate for compound 3 lay 2.5-fold (0.40 log units) above the measured number; the measured number falls inside the stated range.
By their numbers in this assay, from the lowest: compounds 2 and 3 (each within the scatter of the next); then compound 1.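

In this assay, methoxy in place of nitro on this aromatic carbon, para to a large group, gives no change at the digits printed from compound 2 to compound 3 (within the scatter), so these two groups are not separated here. The change to 4-methoxyphenyl from 3-hydroxyphenyl gives a 5.0-fold lower number from compound 1 to compound 3 (0.70 log units; beyond the scatter), so methoxy at this place does not carry the higher number of compound 1. No measured evidence bears on this result. Open, as far as these compounds go, is whether the gap to compound 1 follows the hydroxy group or its place on the ring. Also open, from the compounds shown here alone, is how an amine or a carboxylic acid on this carbon would read.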